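Compound 3: A Small Ring Replaces an Open Chain

A few compounds are considered here, and "the series" means these few. Any claim that something is new, unique, unknown or untested is made for them only; others in the source may bear on it.

Of the compounds shown here, two sharing one core have been measured so far in an in vitro ADME assay on microsomes from liver (Homo sapiens) for metabolic stability; on this read-out lower numbers stand for a shorter-lived compound and higher numbers for a longer-lived compound. Compound 1 (`CC(=O)c1cc(C(=O)NOCCCO)c(Nc2ccc(I)cc2F)n1C`) gives 0.717 h in this test, while compound 2 (`CC(=O)c1cc(C(=O)NOC(CO)CO)c(Nc2ccc(I)cc2F)n1C`) gives 1.5 h and holds the higher of the two numbers. For the measured compounds named here, the only measured step is modest, a 2.1-fold higher number from compound 1 to compound 2 (0.32 log units; beyond the scatter) with 2-hydroxy-1-(hydroxymethyl)ethyl in place of 3-hydroxypropyl on an oxygen. The next compound is compound 3 (`CC(=O)c1cc(C(=O)N2CC(O)C2)c(Nc2ccc(I)cc2F)n1C`), and its difference from compound 2 is a larger one (3-hydroxyazetidin-1-yl in place of (2-hydroxy-1-(hydroxymethyl)ethoxy)amino on a carbonyl carbon) in which 3-hydroxyazetidin-1-yl stands in place of (2-hydroxy-1-(hydroxymethyl)ethoxy)amino on a carbonyl carbon. The measured step changed only the chain on the oxygen, whereas this change removes that oxygen and the whole chain, so it offers only a loose guide. Going by the values given here, no measured compound carries the ring, which leaves no firm basis for a direction. The estimated change is small, a 1.3-fold lower number from compound 2 to compound 3 (0.10 log units; within the scatter) and no step beyond the scatter is expected. In this assay compound 3 is estimated at 1.2 h with an expected range (0.5 h to 3 h) around that figure.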

Compound 3, half-life: 0.25 h
For compound 3 the middle estimate is 4.8-fold (0.68 log units) above the measured one, and the stated range ends above it.
By their numbers in this assay, from the lowest: compound 3; then compound 1; then compound 2.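

Replacing either open chain with 3-hydroxyazetidin-1-yl on the carbonyl carbon shortens the half-life in this assay, with a 6.0-fold lower number from compound 2 to compound 3 (0.78 log units; beyond the scatter) and a 2.9-fold lower number from compound 1 to compound 3 (0.46 log units; beyond the scatter), so compound 3 is the shortest-lived of the three and this position does respond to a change larger than a swap of the chain on the oxygen. The result holds against both chains, so it does not depend on which of the two open chains is taken as the reference. Nothing measured here explains the drop, and no finding on how these compounds are broken down is at hand.

The change does several things at once: the oxygen on the amide nitrogen goes, a four-membered ring enters, and the group falls from 7 heavy atoms to 5, with fewer hydrogen-bond donors and acceptors. The compounds shown cannot separate these parts, and a 3-hydroxypropylamino group on the same carbonyl carbon, which keeps the open chain but lacks that oxygen, would help show whether the ring or the lost oxygen matters more.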